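The source may hold more compounds than are shown below. What is called first, only, known or untested is meant among the compounds shown, and "the series" means these compounds.

Measured in a functional assay on K562 cells (Homo sapiens) for antiproliferative activity, read by MTT assay, with a stated time of 5 days; a lower number here means a stronger inhibitor, a higher number a weaker inhibitor:
- compound 1 `COc1ccc(C(=Cc2ccc(OC)c([N+](=O)[O-])c2)C(=O)c2cc(OC)c(OC)c(OC)c2)cc1`: 2660000 nM
- compound 2 `COc1ccc(/C=C(/C(=O)c2cc(OC)c(OC)c(OC)c2)c2ccc(OC)cc2OC)cc1`: 90000 nM
- compound 3 `COc1ccc(C=C(C(=O)c2cc(OC)c(OC)c(OC)c2)c2ccccc2)cc1[N+](=O)[O-]`: > 10000000 nM (a limit)

Only compound 1 and compound 2 have actual numbers, since the entry for compound 3 is a limit. Compound 2, at 90000 nM, has the lower number, and compound 1 gives 2660000 nM.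

The next compound is compound 4 `COc1ccc(/C=C(/C(=O)c2cc(OC)c(OC)c(OC)c2)c2ccc(N(C)C)cc2)cc1`, which differs from compound 2 by 4-(dimethylamino)phenyl in place of 2,4-dimethoxyphenyl on a double-bonded chain carbon bound to a carbonyl carbon and a double-bonded chain carbon.

For the measured compounds named here, one measured step bears on this group, the exchange of methoxy for hydrogen on an aromatic carbon, an at least 3.7-fold higher number from compound 1 to compound 3 (0.57 log units; beyond the scatter). It shows that this assay can respond to a small aromatic substitution, but it is bounded on one side only and does not test a dimethylamino group. A moderate move to a higher number is therefore expected, though this rests on thin evidence. The expected change is a 3.3-fold higher number from compound 2 to compound 4 (0.52 log units; beyond the scatter). For compound 4 the estimated value is 300000 nM, with an expected range of 30000 nM to 3000000 nM.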

Compound 4, half-maximal inhibitory concentration: 150000 nM
Estimate against measurement, compound 4: 2.0-fold (0.30 log units) above; the range from low to high includes it.
By their numbers in this assay, from the lowest: compounds 2 and 4 (each within the scatter of the next); then compound 1. At a limit, above all of these: compound 3.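

In this assay, 4-(dimethylamino)phenyl in place of 2,4-dimethoxyphenyl on this double-bonded chain carbon gives a 1.7-fold higher number from compound 2 to compound 4 (0.22 log units; within the scatter), so the two compounds cannot be told apart. The earlier compounds had shown only that hydrogen in place of methoxy on the aromatic ring at this carbon, in compounds that also carry a nitro group, moves the number beyond the scatter, whereas this pair shows that a different set of substituents on that ring can leave the number within it. Nothing available explains why this exchange leaves the two compounds within the scatter.

The compounds shown leave open how a primary amine or a carboxylic acid on this ring would read in this assay. They also leave open whether 4-(dimethylamino)phenyl would behave the same way alongside the nitro group of compound 1.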